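The source may hold more compounds than are shown below. What is called first, only, known or untested is meant among the compounds shown, and "the series" means these compounds.

Compound 1 `Cc1ccc(NC(=O)COc2ccc3cc(/C=C4/SC(=O)NC4=O)ccc3c2)cc1Cl` gives 1100 nM in an assay on isolated protein for inhibition of histone deacetylase 4 (Homo sapiens), with a stated time of 1 h (on this read-out higher numbers stand for weaker inhibition and lower numbers for stronger inhibition), compound 2 `O=C(COc1ccc2cc(/C=C3/SC(=O)NC3=O)ccc2c1)Nc1c(F)cc(F)cc1Br` gives 1100 nM, and compound 3 `COc1ccc(NC(=O)COc2ccc3cc(/C=C4/SC(=O)NC4=O)ccc3c2)cc1` gives 4700 nM. Compound 3 stands highest of the three numbers: a 4.3-fold higher number from compound 1 to compound 3 (0.63 log units; beyond the scatter) and a 4.3-fold higher number from compound 2 to compound 3 (0.63 log units; beyond the scatter), whereas no change at the digits printed from compound 1 to compound 2 (within the scatter). Compound 4 `O=C(COc1ccc2cc(/C=C3/SC(=O)NC3=O)ccc2c1)Nc1cccc(C(F)(F)F)c1` differs from compound 3 by 3-(trifluoromethyl)phenyl in place of 4-methoxyphenyl on an amide-type nitrogen. Both measured steps that arrive at compound 3 ran toward a higher number when the 4-methoxyphenyl entered, and the two aryl groups without it gave matching numbers, so for compound 4, which again carries an aryl group without methoxy, a lower number is expected, a 3.6-fold lower number from compound 3 to compound 4 (0.56 log units; beyond the scatter). Compound 4 is therefore estimated at 1300 nM, with a range from 500 nM to 3500 nM.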

Compound 4, half-maximal inhibitory concentration: 2500 nM
The estimate for compound 4 lay 1.9-fold (0.28 log units) below the measured number; the measured number falls inside the stated range.
By their numbers in this assay, from the lowest: compounds 1 and 2 (each within the scatter of the next); then compounds 4 and 3 (each within the scatter of the next).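

At this amide-type nitrogen, losing the 4-methoxyphenyl does not by itself bring the number back to that of the other two aryl groups: a 2.3-fold higher number from compound 1 to compound 4 (0.36 log units; beyond the scatter) and a 2.3-fold higher number from compound 2 to compound 4 (0.36 log units; beyond the scatter) both lie beyond the scatter, while a 1.9-fold lower number from compound 3 to compound 4 (0.27 log units; within the scatter) lies within it. The methoxy group therefore does not alone separate these aryl groups, since compound 4 carries none and still cannot be told apart from compound 3. No measurement at hand accounts for these differences.

Still open, on these data alone, is how a carboxylic acid or an amine on the phenyl ring would read here, and whether 4-(trifluoromethyl)phenyl would match 3-(trifluoromethyl)phenyl.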